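The source may report more compounds than this note shows. Statements on the series, on what has been measured and on what is new or still open speak of the compounds shown alone.

In an assay on COS-7 cells for inhibition of patatin-like phospholipase domain-containing protein 2 (Mus musculus) (on this read-out higher numbers stand for weaker inhibition and lower numbers for stronger inhibition), compound 2 `CCOC(=O)c1cccc(-c2ccc(C)cc2)c1` gives 140000 nM, the highest of the two numbers obtained so far. Its nearest neighbour is compound 1 `CCOC(=O)c1cccc(-c2ccc(OC)cc2)c1`, which in this assay gives 80000 nM; the step of a 1.8-fold higher number from compound 1 to compound 2 (0.24 log units; within the scatter) lies within the scatter, so the two compounds cannot be told apart on this read-out.

Compound 3 `CCOC(=O)c1cccc(-c2ccc(CN3CCCCC3)cc2)c1` is reached from compound 2 by a single change: piperidin-1-yl in place of hydrogen on a saturated chain carbon bound to an aromatic carbon. Going by the values given here, the only step measured so far, the one between compound 1 and compound 2, swaps one small group for another on the aromatic ring and lies within the scatter; it does not involve a change of the kind seen here, and no other measured step does either. The data therefore give no reason to expect a shift in either direction, and an estimate has to stay close to where compound 2 already stands. For compound 3 the expected step is a 1.4-fold lower number from compound 2 to compound 3 (0.15 log units; within the scatter). Compound 3 is accordingly estimated to give 100000 nM, with a range from 20000 nM to 500000 nM.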

Compound 3, half-maximal inhibitory concentration: 75000 nM
Beside the measured number, compound 3's estimate is 1.3-fold (0.12 log units) above it; the measured number falls inside the stated range.
By their numbers in this assay, from the lowest: compounds 3, 1 and 2 (each within the scatter of the next).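

In this assay, putting a piperidin-1-yl group, a saturated ring of 6 heavy atoms, in place of a single hydrogen on the saturated chain carbon gives a 1.9-fold lower number from compound 2 to compound 3 (0.27 log units; within the scatter) and so leaves the read-out unable to separate the two compounds. This is the first sign that a group much larger than a hydrogen can enter at this place without a measurable shift, at least at this level of inhibition, where all the numbers shown lie within the usual scatter of one another. Read against the methoxy compound, the change to (piperidin-1-yl)methyl on an aromatic carbon gives a 1.1-fold lower number from compound 1 to compound 3 (0.03 log units; within the scatter) and tells the same story, and nothing at hand offers an explanation for these results.

As far as these compounds go, whether this holds for other groups at the same place remains open: a morpholine ring, an open-chain dimethylamino group or a carboxylic acid might read differently. From the compounds shown here alone, all three compounds also carry the same ethyl ester, so it is unknown how a free carboxylic acid or an amide in its place would behave on this read-out.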